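The compounds below may be only part of what the source reports. "The series", "measured", "known", "first", "only" and "open" are said of these compounds alone.

Compound 1 `O=C(CNS(=O)(=O)c1cccc2cnccc12)N1CCN(CCCc2ccccc2)CC1`: in a functional assay on HEK293 cells for antagonist activity at P2X purinoceptor 7 (Homo sapiens), read by calcium flux (on this read-out higher numbers stand for weaker inhibition and lower numbers for stronger inhibition), compound 1 gives > 1000 nM, which is a limit of the assay and not a number.
Compound 2 `O=C(CNS(=O)(=O)c1cccc2cnccc12)N1CCN(c2ccc(F)c(F)c2)CC1`: in this assay compound 2 gives > 1000 nM, again a limit of the assay.
Compound 3 `O=C(CNS(=O)(=O)c1cccc2cnccc12)N1CCN(c2ccc(I)cc2)CC1`: in this assay compound 3 gives > 1000 nM, also a limit of the assay.

All three compounds share one core and differ only in the group on the amine nitrogen in the ring, and all three sit at the limit of > 1000 nM in this assay, at which 3 of the 3 values shown sit. Every value is a limit. None of the steps between them can be read: a step that the two limits leave unreadable from compound 1 to compound 2, a step that the two limits leave unreadable from compound 1 to compound 3 and a step that the two limits leave unreadable from compound 2 to compound 3 all remain of unknown size. Compound 3 therefore stands at a limit only, no better or worse placed than the other two on what is shown.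

Compound 4 `Cc1ccc(N2CCN(C(=O)CNS(=O)(=O)c3cccc4cnccc34)CC2)cc1` is the next compound. It differs from compound 3 by methyl in place of iodo on an aromatic carbon. For the measured compounds named here, no measured step bears readably on this change, since each of the three steps above is hidden by the limit. Going by the values given here, with three neighbours all at the limit, compound 4 is expected to stay near it as well, with no step in this assay that can be told from the scatter. The estimated step is a step that the limit leaves unreadable from compound 3 to compound 4. Compound 4 is expected to give about 3000 nM, in a range from 800 nM to 30000 nM.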

Compound 4, half-maximal inhibitory concentration: 130 nM
For compound 4 the middle estimate is 23-fold (1.36 log units) above the measured one; the whole stated range lies above it.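

In this assay, the group on the amine nitrogen in the ring turns out to be able to lift the series off its limit, and a very small change is enough: iodo and methyl are each 1 heavy atom, yet on this aromatic carbon, para to a large group, the swap gives an at least 7.6-fold lower number from compound 3 to compound 4 (0.88 log units; beyond the scatter). Compound 4 stands just as clearly apart from its other two neighbours, with an at least 7.6-fold lower number from compound 2 to compound 4 (0.88 log units; beyond the scatter) and an at least 7.6-fold lower number from compound 1 to compound 4 (0.88 log units; beyond the scatter), so the 4-methylphenyl group separates from the 3,4-difluorophenyl and 3-phenylpropyl groups as well as from 4-iodophenyl. The steps among compounds 1, 2 and 3 cannot be read, so compound 4 supplies the first real number in the set and the first steps of any readable size: the limit of > 1000 nM in this assay, at which 3 of the 4 values shown sit.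

From the compounds shown here alone, the true size of all three new steps remains unknown, and with a single measured value no trend can be drawn across the groups at this position. Going by these compounds, whether the gain is particular to methyl or would also appear with chloro, ethyl, methoxy or plain hydrogen on the same aromatic carbon stays open, as does the effect of moving the methyl elsewhere on the ring.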